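Hydrogen for Methyl: Oral Exposure of Compound 4

The source may report more compounds than this note shows. Statements on the series, on what has been measured and on what is new or still open speak of the compounds shown alone.

Compound 1 `C=C[C@@H]1C[C@]1(NC(=O)[C@@H]1C[C@@H]2CN1C(=O)[C@H](C1CCCCC1)N(C)[C@H](C)CCCCCCc1cccc3c1CN(C3)C(=O)O2)C(=O)NS(=O)(=O)C1CC1` was dosed to rats and followed in an ADME assay on the whole organism (plasma, strain Sprague-Dawley) for pharmacokinetics, with Rattus norvegicus as the target, with a stated time of 4 h, at a dose of 5 mg/kg by the oral route; a lower number here means less compound in the circulation, a higher number more compound in the circulation at the dose given. For compound 1 the assay returned only a limit, < 75.2 ng.h/mL, and not a number. On these data alone, it therefore stands at the low end of what was recorded, though its true value remains unknown. Compound 2 `C=C[C@@H]1C[C@]1(N[C@@H]1C[C@@H]2CN1C(=O)[C@H](C1CCCC1)NCCCCCCCc1ccc3ccnc(c3c1)O2)C(=O)NS(=O)(=O)C1CC1` offers no comparison, its entry being "not determined" (no result reported). Compound 3 `C=C[C@@H]1C[C@]1(N[C@@H]1C[C@@H]2CN1C(=O)[C@H](C1CCCCC1)NCCCCC/C=C/c1cc3c(nccc3cc1OC)O2)C(=O)NS(=O)(=O)C1CC1` gave a measured 4940 ng.h/mL, which shows that a compound of this family can reach a much higher exposure than compound 1. However, compound 3 differs from compound 1 in several places, so it cannot show what any single change contributes.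

Compound 4 `C=C[C@@H]1C[C@]1(NC(=O)[C@@H]1C[C@@H]2CN1C(=O)[C@H](C1CCCCC1)N[C@H](C)CCCCCCc1cccc3c1CN(C3)C(=O)O2)C(=O)NS(=O)(=O)C1CC1` keeps the core of compound 1 and makes a single change: hydrogen in place of methyl on an amine nitrogen in a ring. Within the data shown here, no measured step isolates this change. A modest rise in this assay is expected, with a real chance that the result again falls at a limit. The estimated step is an at least 1.7-fold higher number from compound 1 to compound 4 (0.23 log units; that floor lies within the scatter). For compound 4 the expected value is 130 ng.h/mL, with an estimated range from 35 ng.h/mL to 900 ng.h/mL.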

Compound 4, area under the concentration-time curve: < 73.8 ng.h/mL
Compound 4: only a limit was reported; the forecaster's own chance of this, stated with the estimate: 40%; middle value at least 1.7-fold (0.24 log units) away from the limit.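

In this assay compound 4 returned only a limit, < 73.8 ng.h/mL. Compound 1 also returned only a limit, < 75.2 ng.h/mL. With a limit on each side, no step can be read between compound 1 and compound 4. The compounds shown leave open how far, if at all, hydrogen in place of methyl on this amine nitrogen shifts the result in this assay.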